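The source may hold more compounds than are shown below. What is called first, only, known or untested is meant among the compounds shown, and "the series" means these compounds.

Of the compounds shown here, three have so far been measured in a functional assay on LM7 cells (Homo sapiens) for antiproliferative activity, read by MTT assay, with a stated time of 72 h; on this read-out lower numbers stand for stronger inhibition and higher numbers for weaker inhibition. Compound 1 `O=c1c(CSC(=S)N2CCCCC2)coc2cc(Cl)ccc12` gives 850 nM in this assay. Compound 3 `O=c1c(CSC(=S)N2CCCC2)coc2cc(Cl)ccc12` gives 2600 nM. Compound 2 `COc1ccc2occ(CSC(=S)N3CCCC3)c(=O)c2c1` gives 6000 nM, the highest of the three numbers.

Compound 3 and compound 1 differ in one place only. piperidin-1-yl in place of pyrrolidin-1-yl on a thiocarbonyl carbon The step that went with it was a 3.1-fold lower number from compound 3 to compound 1 (0.49 log units; beyond the scatter). Compound 2 and compound 3 share the same tail but are built on different cores; the difference between the two cores is not broken down here, so the gap between their two values cannot be tied to any single part of the structure.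

Compound 4 `COc1ccc2occ(CSC(=S)N3CCCCC3)c(=O)c2c1` has not yet been measured. Within the data shown here, it differs from compound 2 in this way: piperidin-1-yl in place of pyrrolidin-1-yl on a thiocarbonyl carbon This is the same change, at the same place, as the one from compound 3 to compound 1. Among the measured compounds shown here, the expected step from compound 2 to compound 4 is a 3.2-fold lower number from compound 2 to compound 4 (0.50 log units; beyond the scatter), which rests on the single earlier step of a 3.1-fold lower number from compound 3 to compound 1 (0.49 log units; beyond the scatter). One example on a different core is thin ground. The estimate therefore carries a wide range. Compound 4 is expected to give 1900 nM, with a likely spread from 900 nM to 4500 nM.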

Compound 4, half-maximal inhibitory concentration: 4700 nM
Compound 4: the middle estimate sits 2.5-fold (0.39 log units) below what was measured; the whole stated range lies below it.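

In this assay, among these compounds, putting piperidin-1-yl in place of pyrrolidin-1-yl on the thiocarbonyl carbon of the core of compound 2 gives a 1.3-fold lower number from compound 2 to compound 4 (0.11 log units; within the scatter), so on this core the change produces no step that can be told apart from ordinary repeat variation. Set beside the earlier result on the other core, the new step cannot be said to differ from it: the same change on two cores in this assay, a 3.1-fold lower number (0.49 log units; beyond the scatter) from compound 3 to compound 1 and a 1.3-fold lower number (0.11 log units; within the scatter) from compound 2 to compound 4, 2.4-fold (0.38 log units) apart, within the scatter of two such steps. This shows that the two results are compatible with a single modest effect of the change on both cores, or with no effect on either once measurement scatter is allowed for, but it does not show that the step seen on one core reliably carries over to another, nor does it show that the core alters the step, since two pairs of compounds cannot settle either point.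

The compounds shown leave open how other groups on the thiocarbonyl carbon would compare, such as a morpholin-4-yl ring or an open-chain diethylamino group. They also leave open whether the same swap on further cores would give a clear step or none, which more matched pairs of compounds could help to decide.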